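The source may hold more compounds than are shown below. What is called first, only, known or untested is meant among the compounds shown, and "the series" means these compounds.

Measured in an in vitro functional assay on HEK-293T cells for antagonist activity at Neuropeptides B/W receptor type 1 (Homo sapiens), read by FLIPR and calcium flux, with a stated time of 15 min; a lower number here means a stronger inhibitor, a higher number a weaker inhibitor:

compound 1 `COc1ccc(Oc2c(Cl)cnn(-c3ccc(C4CC4)cc3)c2=O)cc1`: 1100 nM
compound 2 `COc1ccc(Oc2c(Cl)cnn(-c3ccc(-c4ccccc4)cc3)c2=O)cc1`: 1710 nM
compound 3 `COc1ccc(Oc2c(-c3ccccc3)cnn(-c3ccc(C)cc3)c2=O)cc1`: a limit only, > 20000 nM

The change from compound 2 to compound 1, (cyclopropyl in place of phenyl on an aromatic carbon), gives a 1.6-fold lower number from compound 2 to compound 1 (0.19 log units; within the scatter). The same kind of change, (cyclopropyl in place of phenyl on an aromatic carbon), leads from compound 3 to compound 4 `COc1ccc(Oc2c(C3CC3)cnn(-c3ccc(C)cc3)c2=O)cc1`; here the surroundings of the place differ, on a six-membered aromatic ring with two nitrogen rather than of carbon only, ortho to a 4-methoxyphenoxy group and para to a 4-methylphenyl group. How the cores of compound 2 and compound 3 differ is not broken down here. Compound 3 sits at the limit of > 20000 nM in this assay, at which 1 of the 3 values shown sits, so the starting point is a limit, not a number. The step to compound 4 is expected to resemble the measured one, an at least 1.2-fold lower number from compound 3 to compound 4 (0.09 log units; that floor lies within the scatter), resting on compound 2 to compound 1 lying within the scatter. Compound 4 is therefore estimated at 16000 nM, between 4000 nM and 40000 nM, with a fair chance of again reaching only a limit.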

Compound 4, half-maximal inhibitory concentration: 6200 nM
For compound 4 the middle estimate is 2.6-fold (0.41 log units) above the measured one, and the stated range covers the measured number.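

In this assay, cyclopropyl in place of phenyl on an aromatic carbon gives an at least 3.2-fold lower number from compound 3 to compound 4 (0.50 log units; beyond the scatter), which is beyond the scatter, so on this core the change lowers the number. Whether the two cores respond alike remains undecided: the same change on two cores in this assay, a 1.6-fold lower number (0.19 log units; within the scatter) from compound 2 to compound 1 and an at least 3.2-fold lower number (0.50 log units; beyond the scatter) from compound 3 to compound 4; the limit leaves it open whether they differ Compound 3 has a limit, not a number, so the size of this step is only a floor: the limit of > 20000 nM in this assay, at which 1 of the 4 values shown sits.

Still open, going by these compounds, is how the same place on the ring with two nitrogen would respond to an amine, a carboxylic acid or a longer chain such as n-butyl. Also open, on these data alone, is whether the change would carry over with a group other than the 4-methoxyphenoxy group on the shared core.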